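Compound 1 and a side-group swap

This account rests on a few compounds, and the source may have more. Where it says the series, first, only, none or still open, it means among the compounds named here.

Compound 1 `O=C(NCc1cc(Cl)ccc1-n1cnnn1)[C@@H]1C[C@@H]2C[C@@H]2N1C(=O)[C@H](O)Cn1cccn1`: 0.45 10^-6 cm/s
Compound 2 `CC(C)(C)[C@@H](O)C(=O)N1C[C@H]2C[C@H]2[C@H]1C(=O)NCc1cc(Cl)ccc1-n1cnnn1`: 3.8 10^-6 cm/s

In an ADME assay on Caco-2 cells (Homo sapiens) for permeability, read by LC-MS, in the apical to basolateral direction, with a stated time of 60 min, at pH 6.5 (on this read-out lower numbers stand for lower permeability and higher numbers for higher permeability), compound 1, at 0.45 10^-6 cm/s, holds the lower of the two numbers, and compound 2 stands higher by more than the usual scatter. Compound 3 `O=C(NCc1cc(Cl)ccc1-n1cnnn1)[C@@H]1C[C@@H]2C[C@@H]2N1C(=O)[C@H](O)c1ccccc1` differs from compound 1 in one place phenyl in place of (1H-pyrazol-1-yl)methyl on a saturated chain carbon bound to a carbonyl carbon and an oxygen on a saturated carbon. Within the data shown here, no measured pair shows this change, so the expectation is loose. It leans on compound 2, whose 3.8 10^-6 cm/s shows that a higher number is reachable. In this assay the expected step is a 3.3-fold higher number from compound 1 to compound 3 (0.52 log units; beyond the scatter), a rise beyond the scatter. For compound 3 the estimate is 1.5 10^-6 cm/s, with an expected range from 0.6 10^-6 cm/s to 4 10^-6 cm/s.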

Compound 3, apparent permeability: 8 10^-6 cm/s
For compound 3 the middle estimate is 5.3-fold (0.73 log units) below the measured one; the measured number lies above the stated range.
By their numbers in this assay, from the lowest: compound 1; then compound 2; then compound 3.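

At the saturated chain carbon bound to a carbonyl carbon and an oxygen, a single swap has a large effect: in this assay, phenyl in place of (1H-pyrazol-1-yl)methyl gives an 18-fold higher number from compound 1 to compound 3 (1.25 log units; beyond the scatter) in apparent permeability. Both groups hold 6 heavy atoms, so this step comes without a change in that count, although the ring and its atoms differ. Nothing measured here explains the step. As far as these compounds go, how an amine, a carboxylic acid or a longer chain at this carbon would read in this assay remains open.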